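The source may hold more compounds than are shown below. What is called first, only, known or untested is meant among the compounds shown, and "the series" means these compounds.

Of the compounds shown here, three have been measured in a functional assay on HeLa cells (Homo sapiens) for cytotoxicity, read by LDH release, with a stated time of 48 h; a lower number here means a stronger inhibitor, a higher number a weaker inhibitor. Compound 1 (`O=C(COc1c(F)cc(C(=O)c2ccc(F)cc2)cc1Cl)NNC(=O)c1ccc(=O)oc1`) gives 60100 nM, compound 2 (`Cc1ccc(C(=O)c2cc(F)c(OCC(=O)NNC(=O)c3ccc(=O)oc3)c(Cl)c2)cc1`) gives 26900 nM, and compound 3 (`Cn1cnc(C(=O)NNC(=O)COc2c(F)cc(C(=O)c3ccc(Cl)cc3)cc2Cl)c1`) gives 54500 nM. Compound 3 thus lies within the scatter of compound 1, while the number of compound 2 lies beneath both, beyond the scatter.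

Compound 4 (`O=C(COc1c(F)cc(C(=O)c2ccc(Cl)cc2)cc1Cl)NNC(=O)c1ccc(=O)oc1`) differs from compound 3 in one place, on a carbonyl carbon: a group of 7 heavy atoms (5 carbon, 2 oxygen; one six-membered aromatic ring with 1 hetero atom) in place of a group of 6 heavy atoms (4 carbon, 2 nitrogen; one five-membered aromatic ring with 2 hetero atoms), on a carbonyl carbon. Within the data shown here, the 1-methyl-1H-imidazol-4-yl group leaves, and the entering group is the one already carried by compound 1 and compound 2. Among the measured compounds shown here, no measured step covers this exchange directly. For the measured compounds named here, the only step available is a 2.2-fold lower number from compound 1 to compound 2 (0.35 log units; beyond the scatter), a modest one, with methyl in place of fluoro on an aromatic carbon, and it concerns another part of the molecule. The closeness of compound 1 at 60100 nM to compound 3 gives no sign of a large shift. The expected change is therefore small, a 1.4-fold lower number from compound 3 to compound 4 (0.13 log units; within the scatter), and no step beyond the scatter is expected. For compound 4 the estimated value is 40000 nM, with an expected range from 18000 nM to 85000 nM.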

Compound 4, half-maximal inhibitory concentration: 85100 nM
For compound 4 the middle estimate is 2.1-fold (0.33 log units) below the measured one, and the stated range ends below it.
By their numbers in this assay, from the lowest: compound 2; then compounds 3, 1 and 4 (each within the scatter of the next).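

In this assay, the group carried by compound 1 and compound 2 in place of the 1-methyl-1H-imidazol-4-yl group on the carbonyl carbon gives a 1.6-fold higher number from compound 3 to compound 4 (0.19 log units; within the scatter), so this one pair does not separate the two groups. On the aromatic carbon, chloro in place of fluoro gives a 1.4-fold higher number from compound 1 to compound 4 (0.15 log units; within the scatter), while chloro in place of methyl gives a 3.2-fold higher number from compound 2 to compound 4 (0.50 log units; beyond the scatter); with the chloro compound now in hand, the methyl of compound 2 stands apart from both halogens, and the fluoro and chloro compounds cannot be told apart. Nothing available accounts for these steps.

From the compounds shown here alone, each comparison rests on a single pair, so it remains open whether the same steps would hold on another background. Going by these compounds, what a methoxy group or an amine on that aromatic carbon, or a plain phenyl ring on the carbonyl carbon, would give also remains open.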